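The source may hold more compounds than are shown below. What is called first, only, known or untested is meant among the compounds shown, and "the series" means these compounds.

Measured in a functional assay on U-87MG ATCC cells for antiproliferative activity against U-87 MG (Homo sapiens), with a stated time of 5 days; a lower number here means that less compound is needed, a higher number that more compound is needed for the effect:
- compound 1 `Nc1nc2cc(-c3nn(CC4OCCO4)c4ncnc(N)c34)ccc2o1`: 100 nM
- compound 2 `Nc1nc2cc(-c3nn(C[C@@H]4CCCO4)c4ncnc(N)c34)ccc2o1`: 100 nM

Going by the values given here, compound 2 stands level with the only other measured compound at the digits given, so the series offers no spread to work from. Compound 3 `COC(Cn1nc(-c2ccc3oc(N)nc3c2)c2c(N)ncnc21)OC` is the next case: dimethoxymethyl in place of oxolan-2-yl on a saturated chain carbon bound to an aromatic nitrogen. In words, this is dimethoxymethyl in place of oxolan-2-yl on a saturated chain carbon bound to an aromatic nitrogen. Among the compounds with values here, the one measured step that bears on it is no change at the digits printed from compound 1 to compound 2 (within the scatter), with oxolan-2-yl in place of 1,3-dioxolan-2-yl at the same place. That step is a change between two ring groups, and no group without a ring has been measured here, so the support is thin. No step beyond the scatter is expected in this assay, and no direction is favoured. The estimated step is a 1.3-fold higher number from compound 2 to compound 3 (0.11 log units; within the scatter). Compound 3 is estimated at 130 nM, with an expected range of 45 nM to 400 nM.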

Compound 3, half-maximal effective concentration: 100 nM
Compound 3: middle estimate off by 1.3-fold (0.11 log units), on the high side, and the stated range covers the measured number.
By their numbers in this assay, from the lowest: compounds 1, 2 and 3 (each within the scatter of the next).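

In this assay the ring on the saturated chain carbon bound to an aromatic nitrogen is not required for a number at this level: dimethoxymethyl in place of oxolan-2-yl gives no change at the digits printed from compound 2 to compound 3 (within the scatter) and dimethoxymethyl in place of 1,3-dioxolan-2-yl gives no change at the digits printed from compound 1 to compound 3 (within the scatter) in the same assay. The two earlier compounds compared only ring groups, whereas compound 3 extends the flat reading to a group with no ring and no defined stereocentre. No supporting data bear on why these groups read alike.

Still open, from the compounds shown here alone, is whether this tolerance extends beyond oxygen-bearing groups of this size at this place, for example to an amine, a carboxylic acid or a longer chain. The mirror-image form of the oxolan-2-yl group in compound 2 also remains an open comparison.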